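Swapping hydroxy for hydroxymethyl on a hydroxamic acid

The source may report more compounds than this note shows. Statements on the series, on what has been measured and on what is new or still open speak of the compounds shown alone.

Compound 1 `COc1ccccc1-c1cc(/C=C/c2ccc(C(=O)NO)cc2)ccn1`: 28 nM
Compound 2 `O=C(NO)c1ccc(/C=C/c2ccnc(-c3cccc(O)c3)c2)cc1`: 19 nM

Both compounds were tested in an assay on isolated protein for inhibition of protein deacetylase HDAC6 (Homo sapiens), read by fluorescence, with a stated time of 15 min; a higher number here means a weaker inhibitor, a lower number a stronger inhibitor. For the measured compounds named here, the one step between them, a 1.5-fold lower number from compound 1 to compound 2 (0.17 log units; within the scatter), lies within the scatter, so compound 2 and compound 1 cannot be told apart on these numbers. Compound 3 `O=C(NO)c1ccc(/C=C/c2ccnc(-c3cccc(CO)c3)c2)cc1` differs from compound 2 in one place: hydroxymethyl in place of hydroxy on an aromatic carbon. Going by the values given here, the only measured step, a 1.5-fold lower number from compound 1 to compound 2 (0.17 log units; within the scatter), exchanged one group for another on the same part of the molecule and did not move the number beyond the scatter. Among the compounds with values here, no measured step exchanges hydroxy for hydroxymethyl, so there is no direct precedent. Within the data shown here, with only that neighbouring step to go by, the step of a 1.3-fold higher number from compound 2 to compound 3 (0.12 log units; within the scatter) is expected to stay within the scatter. The estimate for compound 3 is 25 nM, with a range from 10 nM to 65 nM.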

Compound 3, half-maximal inhibitory concentration: 34 nM
For compound 3 the middle estimate is 1.4-fold (0.13 log units) below the measured one; the measured number falls inside the stated range.
By their numbers in this assay, from the lowest: compounds 2, 1 and 3 (each within the scatter of the next).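

In this assay, for the compounds shown here, hydroxymethyl in place of hydroxy gives a 1.8-fold higher number from compound 2 to compound 3 (0.25 log units; within the scatter), so the first exchange of a group at this place for a close relative of itself also leaves the number within the scatter. The comparison with the 2-methoxyphenyl group gives a 1.2-fold higher number from compound 1 to compound 3 (0.08 log units; within the scatter), which means that all three substituted phenyl groups in this set now give numbers that cannot be told apart. The added carbon of hydroxymethyl therefore brings no readable change here, and this small set shows no ranking among the three groups.

On these data alone, whether an amine, a carboxylic acid or a longer chain such as hydroxyethyl on the same aromatic carbon would also stay within the scatter remains open. Nothing given here speaks to why these three numbers lie so close together.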